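Methyl for Trifluoromethyl on the Benzamide Ring

The compounds below may be only part of what the source reports. "The series", "measured", "known", "first", "only" and "open" are said of these compounds alone.

Measured compounds:
Compound 1, `NC(=O)c1c(NC(=O)c2ccc(C(F)(F)F)cc2)sc2c1CCN(Cc1ccccc1F)C2`, 26900 nM
Compound 2, `NC(=O)c1c(NC(=O)c2ccc(C(F)(F)F)cc2)sc2c1CCN(Cc1ccc(Cl)cc1Cl)C2`, 10900 nM

Within the data shown here, in a functional assay on MKN-74 cells (Homo sapiens) for antiproliferative activity, with a stated time of 24 h (a higher number here means a weaker inhibitor, a lower number a stronger inhibitor), compound 2 holds the lower of the two numbers, and the step of a 2.5-fold lower number from compound 1 to compound 2 (0.39 log units; beyond the scatter) is the only measured change. Compound 3, `Cc1ccc(C(=O)Nc2sc3c(c2C(N)=O)CCN(Cc2ccc(Cl)cc2Cl)C3)cc1`, differs from compound 2 in one place: methyl in place of trifluoromethyl on an aromatic carbon. Among the measured compounds shown here, no measured step touches the benzamide ring, so the step from compound 1 to compound 2 does not bear on this change. Compound 3 is therefore expected to show no step beyond the scatter, a 1.1-fold higher number from compound 2 to compound 3 (0.04 log units; within the scatter). The estimate for compound 3 in this assay is 12000 nM, within 4000 nM to 40000 nM.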

Compound 3, half-maximal inhibitory concentration: 25500 nM
Beside the measured number, compound 3's estimate is 2.1-fold (0.33 log units) below it, within the range that was stated.
By their numbers in this assay, from the lowest: compound 2; then compounds 3 and 1 (each within the scatter of the next).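

Among these compounds, this is the first measured change on the benzamide ring, and in this assay the swap from 4-(trifluoromethyl)phenyl to 4-methylphenyl gives a 2.3-fold higher number from compound 2 to compound 3 (0.37 log units; beyond the scatter). The number at this position therefore responds to the group it carries, and with the 2,4-dichlorophenyl group held fixed, trifluoromethyl gives the lower number of the pair. No measurement is at hand that accounts for this step. The compounds shown leave open whether the step holds with the 2-fluorophenyl group of compound 1. They also leave open how a methoxy group, a chlorine atom or an amine would read at this place.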